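Swapping the Aryl Group on a Triazole Nitrogen

The source may report more compounds than this note shows. Statements on the series, on what has been measured and on what is new or still open speak of the compounds shown alone.

In a functional assay on MCF7 cells (Homo sapiens) for antiproliferative activity, read by MTT assay, with a stated time of 48 h (on this read-out higher numbers stand for weaker inhibition and lower numbers for stronger inhibition), compound 1 `N#CC1=C(N)Oc2c(N)cc3nc4ccccc4nc3c2C12C(=O)N(Cc1cnnn1-c1cccc(C(F)(F)F)c1)c1ccccc12` gives 31600 nM. Compound 2 `N#CC1=C(N)Oc2c(N)cc3nc4ccccc4nc3c2C12C(=O)N(Cc1cnnn1-c1ccc([N+](=O)[O-])cc1)c1ccccc12` reaches only the limit of > 50000 nM, so no number is known for it. For the measured compounds named here, the one measured step, an at least 1.5-fold higher number from compound 1 to compound 2 (0.19 log units; that floor lies within the scatter), is the only guide here, and it rests on a limit (the limit of > 50000 nM in this assay, at which 1 of the 2 values shown sits). Compound 3 `Cc1ccc(Cl)cc1-n1nncc1CN1C(=O)C2(C(C#N)=C(N)Oc3c(N)cc4nc5ccccc5nc4c32)c2ccccc21` differs from compound 2 by 5-chloro-2-methylphenyl in place of 4-nitrophenyl on an aromatic nitrogen. Going by the values given here, since the only step at the same aromatic nitrogen stayed within the scatter, no shift beyond the scatter is expected in this assay. Compound 3 is therefore expected near 45000 nM, between 15000 nM and 150000 nM, a change of an at least 1.1-fold lower number from compound 2 to compound 3 (0.04 log units; that floor lies within the scatter).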

Compound 3, half-maximal inhibitory concentration: 43500 nM
Estimate against measurement, compound 3: 1.0-fold (0.01 log units) above; low and high end bracket the measured number.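

For the compounds shown here, this result gives the first step at this aromatic nitrogen that joins two real numbers: in this assay, 5-chloro-2-methylphenyl in place of 3-(trifluoromethyl)phenyl gives a 1.4-fold higher number from compound 1 to compound 3 (0.14 log units; within the scatter). The other new step, an at least 1.1-fold lower number from compound 2 to compound 3 (0.06 log units; that floor lies within the scatter), offers only a floor, so it cannot say how far apart the two compounds lie. Compound 2 stands at a limit and not at a number: the limit of > 50000 nM in this assay, at which 1 of the 3 values shown sits.

All the groups shown at this nitrogen are substituted phenyl rings. From the compounds shown here alone, whether an amine, a carboxylic acid or a longer chain there would shift the number beyond the scatter remains open.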